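Cyclopropyl for methoxycyclobutyl: dog volume of distribution

The compounds below may be only part of what the source reports. "The series", "measured", "known", "first", "only" and "open" are said of these compounds alone.

The three measured compounds and their numbers:

Compound 1 `CCn1c(-c2ccc(C(F)(F)F)nc2)nc2c(O[C@H]3CCN(C(=O)N4CC(OC)C4)C3)ncnc21` gives 1.7 L/kg in an ADME assay (Canis lupus familiaris, strain Beagle) for pharmacokinetics; on this read-out lower numbers stand for narrower distribution and higher numbers for wider distribution into tissues.
Compound 2 `CCn1c(-c2cnc(C)nc2)nc2c(N[C@H]3CCN(C(=O)[C@H]4C[C@@H](OC)C4)C3)ncnc21` gives 2 L/kg in this assay.
Compound 3 `CCn1c(-c2cnc(C)nc2)nc2c(O[C@H]3CCN(C(=O)C4CCOC4)C3)ncnc21` gives 0.9 L/kg in this assay.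

Compound 2 carries the highest of the three numbers. Its nearest neighbour is compound 1, whose value lies within the usual scatter of compound 2, so no order between those two can be read. Compound 3 stands furthest away, and its number is lower than that of compound 2 by more than the scatter. Compounds 1 and 3 each differ from compound 2 in more than one place, so only their values themselves are known, not any single-change step.

Compound 4 `CCn1c(-c2cnc(C)nc2)nc2c(N[C@H]3CCN(C(=O)C4CC4)C3)ncnc21` has not yet been measured in this assay. It differs from compound 2 in one place:

cyclopropyl in place of 3-methoxycyclobutyl on a carbonyl carbon

Going by the values given here, no step between measured compounds matches this change, so the expectation rests on compound 2 alone. Compound 4 is expected to sit close to compound 2, with a step of a 1.1-fold higher number from compound 2 to compound 4 (0.04 log units; within the scatter) that stays within the scatter. The estimate for compound 4 in this assay is 2.2 L/kg, with a range from 1.2 L/kg to 4 L/kg.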

Compound 4, volume of distribution: 1.8 L/kg
For compound 4 the middle estimate is 1.2-fold (0.09 log units) above the measured one; the range from low to high includes it.
By their numbers in this assay, from the lowest: compounds 3, 1, 4 and 2 (each within the scatter of the next, the first and the last beyond it).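

Going by these compounds alone, the single change at this place gives a 1.1-fold lower number from compound 2 to compound 4 (0.05 log units; within the scatter) in this assay and so offers the first direct comparison on this carbonyl carbon, which the earlier compounds could not provide. The step lies within the scatter, so no change in tissue distribution can be read between these two compounds. This holds even though the group that leaves has 6 heavy atoms, 1 hydrogen-bond acceptor and 2 defined stereocentres, while the cyclopropyl that enters has 3 heavy atoms and no hydrogen-bond acceptor, and nothing shown here explains why the two compounds read alike.

The compounds shown leave open whether a carboxylic acid or an amine on this carbonyl carbon would give a step beyond the scatter, as the only pair here compares two neutral ring groups. They also leave open whether cyclopropyl in place of 3-methoxycyclobutyl would read the same way in a compound that differs from compound 2 elsewhere on the shared core.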